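Nitro in Place of Ethoxy on the Shared Core

This account rests on a few compounds, and the source may have more. Where it says the series, first, only, none or still open, it means among the compounds named here.

Compound 1 `CS(=O)(=O)c1ccc2nc(NC(=O)CCCCC(=O)NO)sc2c1` carries a methylsulfonyl group on an aromatic carbon of its core. In a functional assay on SW-620 cells (Homo sapiens) for cytotoxicity (on this read-out higher numbers stand for weaker inhibition and lower numbers for stronger inhibition), compound 1 gives only a limit, > 30 ug/mL, so no number is known for it. Compound 2 `CCOc1ccc2nc(NC(=O)CCCCC(=O)NO)sc2c1`, with ethoxy in place of methylsulfonyl, gives 9.26 ug/mL in this assay. The step of an at least 3.2-fold lower number from compound 1 to compound 2 (0.51 log units; beyond the scatter) is the only measured step, and compound 2 holds the only number shown, the other value being a limit (the limit of > 30 ug/mL in this assay, at which 1 of the 2 values shown sits). Compound 3 `O=C(CCCCC(=O)Nc1nc2ccc([N+](=O)[O-])cc2s1)NO` differs from compound 2 by nitro in place of ethoxy on an aromatic carbon. Among the measured compounds shown here, the single measured step bears on this change only in that it alters the same carbon, where ethoxy gave the stronger number. The expected outcome is a weaker number for compound 3, a step of a 2.2-fold higher number from compound 2 to compound 3 (0.33 log units; beyond the scatter) in this assay, with a fair chance of a limit. Compound 3 is therefore estimated at 20 ug/mL, within 7 ug/mL to 60 ug/mL.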

Compound 3, half-maximal inhibitory concentration: > 30 ug/mL
Compound 3: only a limit was reported; the forecaster's own chance of this, stated with the estimate: 40%; middle value at least 1.5-fold (0.17 log units) away from the limit.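

In this assay, putting nitro on this aromatic carbon gives an at least 3.2-fold higher number from compound 2 to compound 3 (0.51 log units; beyond the scatter), so a second group in place of ethoxy, after methylsulfonyl, also moves the read-out to the weaker side, and compound 2 remains the only one of the three with an actual number. The step between the methylsulfonyl and nitro compounds cannot be read, as both values are limits, and these two groups cannot be ranked against each other. The limit now accounts for most of the series: the limit of > 30 ug/mL in this assay, at which 2 of the 3 values shown sit.

As far as these compounds go, the true numbers of compound 1 and compound 3 remain unknown. Also open, from the compounds shown here alone, is whether an amine, a methoxy group or a longer alkoxy chain on this carbon would give a number near that of compound 2 or a lower one.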